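The source may report more compounds than this note shows. Statements on the series, on what has been measured and on what is new or still open speak of the compounds shown alone.

Measured in an ADME assay on L02 cells (Homo sapiens) for cytotoxicity, read by MTT assay, with a stated time of 72 h (on this read-out higher numbers stand for weaker inhibition and lower numbers for stronger inhibition), each value being a limit and not a number:
- Compound 1 `C/C=C/C(=O)Nc1cccc(Oc2nc(Nc3ccn(C)n3)nc3c2CSCC3)c1` gives > 50000 nM as a limit
- Compound 2 `CCC/C=C/C(=O)Nc1cccc(Oc2nc(Nc3ccn(C)n3)nc3c2CSCC3)c1` gives > 50000 nM as a limit
- Compound 3 `CC(C)=CC(=O)Nc1cccc(Oc2nc(Nc3ccn(C)n3)nc3c2CSCC3)c1` gives > 50000 nM as a limit

Compound 2 has no number of its own, only the limit > 50000 nM in this series. It stands with its two companions, and the series as a whole shows nothing beyond the limit of > 50000 nM in this assay, at which 3 of the 3 values shown sit, as its single result.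

Compound 4 `CCC/C=C/C(=O)Nc1cccc(Oc2nc(Nc3cccc(C#N)c3)nc3c2CSCC3)c1` keeps the pent-1-en-1-yl group on the carbonyl carbon of compound 2 and differs on a nitrogen: 3-cyanophenyl in place of 1-methyl-1H-pyrazol-3-yl on a nitrogen on an aromatic ring is the whole change. In words, 3-cyanophenyl stands in place of 1-methyl-1H-pyrazol-3-yl on a nitrogen on an aromatic ring.

The measured steps are a step that the two limits leave unreadable from compound 1 to compound 2 and a step that the two limits leave unreadable from compound 1 to compound 3 and also a step that the two limits leave unreadable from compound 2 to compound 3 in the same series. All three alter the group on the carbonyl carbon, none touches the group on that nitrogen, and none has a readable size, so they set no size for this change.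

Among the compounds with values here, the only anchor is compound 2 at the limit > 50000 nM and so a modest move towards stronger inhibition, or none, is expected. The expected change is an at least 1.2-fold lower number from compound 2 to compound 4 (0.09 log units; that floor lies within the scatter) as an estimate with a wide margin. In this assay compound 4 is expected at 40000 nM with an estimated range from 12000 nM to 100000 nM around it.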

Compound 4, half-maximal inhibitory concentration: > 50000 nM
Compound 4: no number, only a limit; the forecaster's own chance of this, stated with the estimate: 60%; middle value at least 1.2-fold (0.09 log units) from the limit.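

In this assay compound 4 gives > 50000 nM, which is a limit and not a number. Within the data shown here, compound 2 also has only a limit, so no step between compound 2 and compound 4 can be read. The series shows a single result: the limit of > 50000 nM in this assay, at which 4 of the 4 values shown sit.

The compounds shown leave open what actual values lie behind these limits, and whether either change affects them.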